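The source may hold more compounds than are shown below. What is called first, only, known or untested is meant among the compounds shown, and "the series" means these compounds.

Compound 1 `C#CCOc1ccc2c(=O)c(-c3cc(OC)c(OC)cc3OC)coc2c1` — 8050 nM
Compound 2 `COc1cc(OC)c(-c2coc3cc(OCc4ccccc4C)ccc3c2=O)cc1OC` — 2900 nM
Compound 3 `COc1cc(OC)c(-c2coc3cc(OCc4ccc([N+](=O)[O-])cc4)ccc3c2=O)cc1OC` — a limit of the assay, > 10000 nM

All three compounds share one core and differ only in the group on a saturated chain carbon bound to an oxygen on an aromatic ring. In a functional assay on HCT-116 cells (Homo sapiens) for antiproliferative activity, read by MTT assay, with a stated time of 24 h (on this read-out higher numbers stand for weaker inhibition and lower numbers for stronger inhibition), compound 1 gives 8050 nM, which is the higher of the two numbers recorded; compound 2 gives 2900 nM. For compound 3 the assay reports only a limit (the limit of > 10000 nM in this assay, at which 1 of the 3 values shown sits).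

Compound 4 `COc1cc(OC)c(-c2coc3cc(OCc4ccc(C#N)cc4)ccc3c2=O)cc1OC` is the next member of the series. It differs from compound 1 as follows: 4-cyanophenyl in place of ethynyl on a saturated chain carbon bound to an oxygen on an aromatic ring. Within the data shown here, two measured steps bear on this change. Replacing ethynyl with 2-methylphenyl gave a 2.8-fold lower number from compound 1 to compound 2 (0.44 log units; beyond the scatter), whereas replacing it with 4-nitrophenyl gave an at least 1.2-fold higher number from compound 1 to compound 3 (0.09 log units; that floor lies within the scatter), with the latter step bounded by the limit. The new 4-cyanophenyl, like 4-nitrophenyl, is a phenyl carrying a single substituent, and the two steps point in opposite directions, so no large movement beyond the scatter is expected in either direction.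

Compound 4 is therefore estimated at 9000 nM, within a range from 4000 nM to 20000 nM, which is expected to correspond to a 1.1-fold higher number from compound 1 to compound 4 (0.05 log units; within the scatter).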

Compound 4, half-maximal inhibitory concentration: 4220 nM
Compound 4: middle estimate off by 2.1-fold (0.33 log units), on the high side; the measured number falls inside the stated range.
By their numbers in this assay, from the lowest: compounds 2, 4 and 1 (each within the scatter of the next, the first and the last beyond it). At a limit, above all of these: compound 3.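

In this assay, the two phenyl groups carrying a single substituent do not read alike at this position: with cyano in place of nitro on an aromatic carbon, the result is an at least 2.3-fold lower number from compound 3 to compound 4 (0.37 log units; beyond the scatter), so the earlier weak reading of compound 3 does not extend to every 4-substituted phenyl group shown here. That comparison has only one firm end, and the figure for compound 3 is a limit rather than a number: the limit of > 10000 nM in this assay, at which 1 of the 4 values shown sits. Among these compounds, exchanging the propargyl of the first compound for 4-cyanobenzyl gives a 1.9-fold lower number from compound 1 to compound 4 (0.28 log units; within the scatter), and exchanging 2-methylphenyl for 4-cyanophenyl gives a 1.5-fold higher number from compound 2 to compound 4 (0.16 log units; within the scatter), so compound 4 is not separated from either neighbour and no simple ranking of ethynyl against aromatic groups emerges on this carbon.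

The compounds shown leave open whether the weak reading of compound 3 belongs to the nitro group alone, which a 4-aminophenyl or a 4-carboxyphenyl group on the same carbon would help to settle. They also cannot separate the identity of a substituent from its place on the ring, a question that a 4-methylphenyl group set against the 2-methylphenyl of compound 2 would address.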